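The source may report more compounds than this note shows. Statements on the series, on what has been measured and on what is new or still open speak of the compounds shown alone.

In a functional assay on PC-3 cells (Homo sapiens) for antiproliferative activity, read by MTT assay, with a stated time of 48 h (on this read-out lower numbers stand for stronger inhibition and higher numbers for weaker inhibition), compound 1 (`CCN(CC)CCNC(=O)c1ccc(C(CC)(CC)c2ccc(OCCC(O)(CC)CC)c(C)c2)n1CC`) gives 3350 nM, compound 2 (`C#CC(C)OC(=O)c1ccc(C(CC)(CC)c2ccc(OCCC(O)(CC)CC)c(C)c2)n1CC`) gives 14800 nM and compound 3 (`CCOC(=O)CN(C)C(=O)c1ccc(C(CC)(CC)c2ccc(OCCC(O)(CC)CC)c(C)c2)n1CC`) gives 7140 nM, the middle of the three numbers. Compound 4 (`CCC(C)C(NC(=O)c1ccc(C(CC)(CC)c2ccc(OCCC(O)(CC)CC)c(C)c2)n1CC)C(=O)O`) carries (1-carboxy-2-methylbutyl)amino in place of ((ethoxycarbonyl)methyl)(methyl)amino on a carbonyl carbon. Three measured changes at this same place bear on it: a 4.4-fold higher number from compound 1 to compound 2 (0.65 log units; beyond the scatter), a 2.1-fold higher number from compound 1 to compound 3 (0.33 log units; beyond the scatter) and a 2.1-fold lower number from compound 2 to compound 3 (0.32 log units; beyond the scatter), all modest. Among the compounds with values here, no measured compound carries a carboxy group, so direction is weakly supported. The expected change is a 1.7-fold higher number from compound 3 to compound 4 (0.23 log units; within the scatter), leaning towards a higher number and no larger than the measured steps. For compound 4 the estimate is 12000 nM, with an expected range of 4000 nM to 35000 nM.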

Compound 4, half-maximal inhibitory concentration: 13800 nM
Compound 4: the middle estimate sits 1.2-fold (0.06 log units) below what was measured, and the stated range covers the measured number.
By their numbers in this assay, from the lowest: compound 1; then compounds 3, 4 and 2 (each within the scatter of the next, the first and the last beyond it).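

In this assay, a carboxylic acid at this place on the carbonyl carbon gives a 1.9-fold higher number from compound 3 to compound 4 (0.29 log units; within the scatter) and a 1.1-fold lower number from compound 2 to compound 4 (0.03 log units; within the scatter), so compound 4 stays within the scatter of both compound 2 and compound 3, although those two lie beyond the scatter of each other. The amine-bearing 2-(diethylamino)ethyl group remains apart, with a 4.1-fold higher number from compound 1 to compound 4 (0.61 log units; beyond the scatter). No available evidence accounts for these steps.

Open, on these data alone, is whether the amine in compound 1 goes with its lower number, which a plain butyl chain in its place would separate. The methyl ester of the 1-carboxy-2-methylbutyl group would likewise separate the free acid from its branched chain.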